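The source may report more compounds than this note shows. Statements on the series, on what has been measured and on what is new or still open speak of the compounds shown alone.

Compound 1 `Cc1ccc(-c2ccc(C(=O)N[C@H](c3nc(C)c(CO)s3)[C@@H]3CCCCN3)[nH]2)cc1F`: 16100 nM
Compound 2 `Cc1ccc(-c2ccc(C(=O)N[C@H](c3nc(C)c(CCO)s3)[C@@H]3CCCCN3)[nH]2)cc1F`: 29700 nM

Only these two compounds have been measured in a toxicity assay on MT2 cells (Homo sapiens) for cytotoxicity, read by XTT assay, with a stated time of 4 days; on this read-out lower numbers stand for higher toxicity in this test and higher numbers for lower toxicity in this test. Compound 2, at 29700 nM, holds the higher of the two numbers, but it lies within the scatter of compound 1, so the pair cannot be ranked. Compound 3 `Cc1nc([C@@H](NC(=O)c2ccc(-c3ccc(Cl)c(F)c3)[nH]2)[C@@H]2CCCCN2)sc1CCO` departs from compound 2 on the aromatic ring of carbon only: chloro in place of methyl on an aromatic carbon. This is chloro in place of methyl on an aromatic carbon, turning 3-fluoro-4-methylphenyl into 4-chloro-3-fluorophenyl. Among the measured compounds shown here, no measured step touches that site. For the measured compounds named here, the only step available, a 1.8-fold higher number from compound 1 to compound 2 (0.27 log units; within the scatter), is a different change, hydroxymethyl in place of hydroxy on a saturated chain carbon bound to an aromatic carbon. It shows that this part of the series stayed within the scatter in this assay, but it gives no size for the new change. With no evidence for a direction, no shift beyond the scatter is expected, and the expected step, a 1.2-fold lower number from compound 2 to compound 3 (0.09 log units; within the scatter), is only an estimate. Compound 3 is estimated at 24000 nM, with an expected range from 10000 nM to 55000 nM.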

Compound 3, half-maximal cytotoxic concentration: 16900 nM
For compound 3 the middle estimate is 1.4-fold (0.15 log units) above the measured one; low and high end bracket the measured number.
By their numbers in this assay, from the lowest: compounds 1, 3 and 2 (each within the scatter of the next).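

In this assay, a change on the aromatic ring of carbon now has a measured size: chloro in place of methyl, turning 3-fluoro-4-methylphenyl into 4-chloro-3-fluorophenyl, gives a 1.8-fold lower number from compound 2 to compound 3 (0.24 log units; within the scatter) in this series, so this swap does not separate the two compounds. Among the compounds shown here, the earlier step concerned only a saturated chain carbon bound to an aromatic carbon, so this result extends the reading to a second site: here too, the one measured change stays within the scatter, although a single swap cannot show that the site as a whole is insensitive. Nothing available on these compounds bears on why this step has the size it has and the result stands as a plain measurement.

The compounds shown leave open whether a different group on this aromatic carbon, such as trifluoromethyl, methoxy, nitrile or an amine, would move the number beyond the scatter. They also leave open whether chloro in place of methyl would give a step of similar size with the hydroxymethyl group of compound 1 in place of the hydroxyethyl chain of compound 2.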